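The source may hold more compounds than are shown below. What is called first, only, known or untested is meant among the compounds shown, and "the series" means these compounds.

Measured so far in a functional assay on CHO cells for agonist activity at adenosine receptor A2b (Homo sapiens), read by scintillation counting and cAMP accumulation, with a stated time of 150 min, in the presence of a further agent that is not named here; a lower number here means a stronger inhibitor, a higher number a weaker inhibitor:
compound 1 `Nc1nc(NCc2ccncc2)nc2sc(-c3ccco3)nc12` gives 33 nM
compound 2 `Nc1nc(NCc2ccco2)nc2sc(-c3ccco3)nc12` gives 82 nM
compound 3 `Nc1nc(NCc2ccccn2)nc2sc(-c3ccco3)nc12` gives 95 nM

Compound 3 carries the highest number of the three in this assay: a 2.9-fold higher number from compound 1 to compound 3 (0.46 log units; beyond the scatter), whereas a 1.2-fold higher number from compound 2 to compound 3 (0.06 log units; within the scatter). Compound 4 `Nc1nc(NCc2ccsc2)nc2sc(-c3ccco3)nc12` differs from compound 3 by thiophen-3-yl in place of pyridin-2-yl on a saturated chain carbon bound to a nitrogen on an aromatic ring. Within the data shown here, the one step that bears on it is the exchange of a six-membered aromatic ring with one hetero atom for a five-membered one at the same place, a 1.2-fold higher number from compound 2 to compound 3 (0.06 log units; within the scatter), which stayed within the scatter; no step to thiophen-3-yl is known. The step from compound 3 to compound 4 is therefore expected to be small, a 1.4-fold lower number from compound 3 to compound 4 (0.13 log units; within the scatter), with the number for compound 4 estimated at 70 nM, range 30 nM to 160 nM.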

Compound 4, half-maximal inhibitory concentration: 8.96 nM
The estimate for compound 4 lay 7.8-fold (0.89 log units) above the measured number, outside the stated range (below it).
By their numbers in this assay, from the lowest: compound 4; then compound 1; then compounds 2 and 3 (each within the scatter of the next).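

Thiophen-3-yl on this saturated chain carbon bound to a nitrogen on an aromatic ring shows that the ring here can move the number far more than the earlier compounds suggested: in this assay the step against pyridin-2-yl is large (an 11-fold lower number from compound 3 to compound 4 (1.03 log units; beyond the scatter)). The step also holds against furan-2-yl (a 9.2-fold lower number from compound 2 to compound 4 (0.96 log units; beyond the scatter)) and pyridin-4-yl (a 3.7-fold lower number from compound 1 to compound 4 (0.57 log units; beyond the scatter)), so ring size alone does not track the number, as the five-membered furan-2-yl of compound 2 shows. Nothing available accounts for the size of these steps.

Open, on these data alone, is whether thiophen-2-yl, furan-3-yl or phenyl on the same carbon would follow compound 4. Also open, as far as these compounds go, is whether a longer chain carrying thiophen-3-yl would keep its number.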